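The source may hold more compounds than are shown below. What is called first, only, known or untested is meant among the compounds shown, and "the series" means these compounds.

In a functional assay on CHO cells with adenosine receptor A1 (Homo sapiens) as the target, read by cAMP accumulation and immunoassay, with a stated time of 6 min, tested at 0.1 uM (on this read-out higher numbers stand for a weaker effect at the one concentration tested and lower numbers for a stronger effect), three compounds have been measured so far:
compound 1 `Nc1scc(CN2CCN(c3ccccc3C(F)(F)F)CC2)c1C(=O)c1ccc(Cl)cc1` gives -7.5%;
compound 2 `Nc1scc(CN2CCC(c3ccc(Cl)cc3)CC2)c1C(=O)c1ccc(Cl)cc1` gives -2.3%;
compound 3 `Nc1scc(CN2CCN(c3ccc(C(F)(F)F)cc3)CC2)c1C(=O)c1cccc(C(F)(F)F)c1` gives -11%.

Compound 1 stands second highest of these three numbers, but its nearest neighbour, compound 3, and its furthest, compound 2, both lie within the usual scatter of it, so the three cannot be told apart on this read-out. Compound 4 `Nc1scc(CN2CCN(c3ccc(F)cc3F)CC2)c1C(=O)c1ccc(Cl)cc1` has not yet been measured. It differs from compound 1 in one place: 2,4-difluorophenyl in place of 2-(trifluoromethyl)phenyl on an amine nitrogen in a ring. Among the measured compounds shown here, no pair of measured compounds differs in one place only, so no single step is known to lean on. With all three measured numbers sitting close together, the expected step from compound 1 to compound 4 is a number 1.5 percentage points higher from compound 1 to compound 4 (within the scatter), none beyond the scatter. Compound 4 is therefore expected to give -6%, somewhere between -20% and 8%.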

Compound 4, a percentage reported as activity, at one concentration (the size of the read-out at that concentration, not a potency): -17%
Compound 4: the middle estimate sits 11 percentage points above what was measured; the measured number falls inside the stated range.
By their numbers in this assay, from the lowest: compounds 4, 3, 1 and 2 (each within the scatter of the next, the first and the last beyond it).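

In this assay, among the compounds shown here, putting 2,4-difluorophenyl in place of 2-(trifluoromethyl)phenyl on the amine nitrogen in the ring gives a number 9.5 percentage points lower from compound 1 to compound 4 (within the scatter), the first change at a single position that can be read here. At this position, then, this swap of one substituted phenyl group for another does not move the number beyond the usual scatter. Nothing available explains the size of this step. On these data alone, whether a pyridine ring or a plain methyl group on this nitrogen would keep the number in the same range remains open.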